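Turning the indole on a triazole-coumarin scaffold

The compounds below may be only part of what the source reports. "The series", "measured", "known", "first", "only" and "open" are said of these compounds alone.

Compound 3 `Cc1c(O)ccc2cc(-n3cc(-c4cc5ccccc5[nH]4)nn3)c(=O)oc12` is tested in a functional assay on MCF7 cells (Homo sapiens) for antiproliferative activity (on this read-out higher numbers stand for weaker inhibition and lower numbers for stronger inhibition), where compound 3 gives 38300 nM. Compound 1 `Cc1c(O)ccc2cc(-n3cc(-c4ccccc4)nn3)c(=O)oc12` gives 25200 nM in this assay; compound 3 holds the higher of these two numbers, yet the step of a 1.5-fold higher number from compound 1 to compound 3 (0.18 log units; within the scatter) stays within the scatter, so the two cannot be separated. Compound 2 `COc1ccc(-c2cn(-c3cc4ccc(O)c(C)c4oc3=O)nn2)cc1` reaches only a limit, > 100000 nM. The step of an at least 2.6-fold lower number from compound 2 to compound 3 (0.41 log units; beyond the scatter) is beyond the scatter. Compound 4 `Cc1c(O)ccc2cc(-n3cc(-c4c[nH]c5ccccc45)nn3)c(=O)oc12` differs from compound 3 by 1H-indol-3-yl in place of 1H-indol-2-yl on an aromatic carbon. Among the measured compounds shown here, no measured step covers an indol-3-yl group, and the one comparable change of this group, a 1.5-fold higher number from compound 1 to compound 3 (0.18 log units; within the scatter), was small, so the estimated step of a 1.0-fold higher number from compound 3 to compound 4 (0.02 log units; within the scatter) is expected to stay within the scatter. Compound 4 is therefore expected to give about 40000 nM, with an estimated range from 13000 nM to 100000 nM.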

Compound 4, half-maximal inhibitory concentration: 8170 nM
Beside the measured number, compound 4's estimate is 4.9-fold (0.69 log units) above it, and the stated range ends above it.
By their numbers in this assay, from the lowest: compound 4; then compounds 1 and 3 (each within the scatter of the next). At a limit, above all of these: compound 2.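

Joining the indole to the triazole through a different ring carbon changes the result even though the atoms stay the same, with a 4.7-fold lower number from compound 3 to compound 4 (0.67 log units; beyond the scatter) in this assay. The 1H-indol-3-yl group also separates from phenyl, with a 3.1-fold lower number from compound 1 to compound 4 (0.49 log units; beyond the scatter), which 1H-indol-2-yl did not do. Compound 2 stands at a limit, so an at least 12-fold lower number from compound 2 to compound 4 (1.08 log units; beyond the scatter) gives only a bound.

The compounds shown leave open whether the indole's ring hydrogen on nitrogen matters. A methyl on that nitrogen, or an amine on the six-membered ring of the indole, could test how far this lower number holds.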